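Adding a chloro to the benzyl group of compound 3

This account rests on a few compounds, and the source may have more. Where it says the series, first, only, none or still open, it means among the compounds named here.

Of the compounds shown here, three have been measured in a functional assay on the whole organism (artery, strain albino) with Rattus norvegicus as the target, with a stated time of 300 min, at a dose of 10 mg/kg by the oral route; a higher number here means more inhibition at the dose given (going by the name of the read-out), a lower number less inhibition. Compound 1 `COc1ccc(C2N=C(SCc3ccc(F)cc3)NC(C)=C2C(=O)Nc2ccc(F)cc2)cc1OC` gives 37.9% in this assay. Compound 2 `CC1=C(C(=O)Nc2ccc(F)cc2)C(c2ccc([N+](=O)[O-])cc2)N=C(SCc2ccc(Cl)cc2)N1` gives 37.9%, the same figure as compound 1. Compound 3 `CC1=C(C(=O)Nc2ccc(Br)cc2)C(c2ccc(Cl)cc2Cl)N=C(SCc2ccccc2)N1` gives 22.1%, the lowest of the three numbers; compound 1 and compound 2 each stand above it by a gap beyond the usual scatter, so the inhibition of compound 3 in this assay is the lowest of the three on the evidence in hand.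

Compound 4 `CC1=C(C(=O)Nc2ccc(Br)cc2)C(c2ccc(Cl)cc2Cl)N=C(SCc2ccc(Cl)cc2)N1` has not yet been measured. It differs from compound 3 in one place: chloro in place of hydrogen on an aromatic carbon. Going by the values given here, no pair of measured compounds isolates this exact change, so its effect cannot be read from a matched step. Compound 2 also carries a 4-chlorobenzyl group, but it differs from compound 3 in other places as well, so its value gives no direct guide.

The step expected is a number 5.9 percentage points higher from compound 3 to compound 4 (within the scatter), a small rise that may well fall within the scatter. Compound 4 is therefore estimated at 28%, with a range from 12% to 45%, pending its measurement.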

Compound 4, a percentage reported as inhibition, in the whole organism at one dose (the size of the read-out at that dose, not a potency): 38.5%
Compound 4: the middle estimate sits 10.5 percentage points below what was measured; measured number inside the range.
By their numbers in this assay, from the lowest: compound 3; then compounds 1, 2 and 4 (each within the scatter of the next).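

Going from benzyl to 4-chlorobenzyl gives a number 16.4 percentage points higher from compound 3 to compound 4 (beyond the scatter) in this assay, the first matched reading of any change in this set. Going by these compounds alone, the earlier compounds could not show this, as they differ from one another in several places at once, whereas here a single chloro on an aromatic carbon, para to a large group, is the only difference and the step lies beyond the usual scatter. The position therefore responds to substitution in at least this one pair, though the data give no account of why the number rises.

On these data alone, what remains open is whether the same step would appear on other versions of the shared core, since a single pair at a single oral dose establishes no trend and says nothing of potency. As far as these compounds go, it is also open whether the rise is particular to chloro or would also follow from an amine, a carboxylic acid or a methyl at the same place, or from a longer chain between the sulfur and the aromatic ring.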